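This account rests on a few compounds, and the source may have more. Where it says the series, first, only, none or still open, it means among the compounds named here.

Compound 1 `COc1ncc(-c2ccc3ncnc(N[C@H]4CCN(C(=O)C5CCOCC5)C4)c3c2)cc1NS(C)(=O)=O`: 1500 nM
Compound 2 `COc1ncc(-c2ccc3ncnc(N[C@H]4CCN(C(C)=O)C4)c3c2)cc1NS(C)(=O)=O`: >= 100000 nM

Among the measured compounds shown here, in a functional assay on SU-DHL-6 cells (Homo sapiens) for antiproliferative activity, read by CCK-8 assay, with a stated time of 72 h (a lower number here means a stronger inhibitor, a higher number a weaker inhibitor), compound 1 gives 1500 nM, the only plain number among the two results. For compound 2 the result is a limit of the assay rather than a number, >= 100000 nM (the limit of >= 100000 nM in this assay, at which 1 of the 2 values shown sits). Compound 3 `COc1ncc(-c2ccc3ncnc(N[C@H]4CCN(C(=O)OC(C)(C)C)C4)c3c2)cc1NS(C)(=O)=O` is not yet measured and differs from compound 1 in one place: tert-butoxy in place of oxan-4-yl on a carbonyl carbon. For the measured compounds named here, the single measured step at this carbonyl carbon, an at least 66-fold higher number from compound 1 to compound 2 (1.82 log units; beyond the scatter), was large and weakening. A smaller loss is expected here because that step an at least 66-fold higher number from compound 1 to compound 2 (1.82 log units; beyond the scatter) swapped the ring for a lone methyl. Compound 3 is therefore estimated at 3500 nM, between 900 nM and 20000 nM, an expected step of a 2.3-fold higher number from compound 1 to compound 3 (0.37 log units; beyond the scatter).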

Compound 3, half-maximal inhibitory concentration: 170 nM
For compound 3 the middle estimate is 21-fold (1.31 log units) above the measured one, outside the stated range (below it).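

In this assay, a change on this carbonyl carbon can strengthen as well as weaken: tert-butoxy, which has no ring, in place of oxan-4-yl gives an 8.8-fold lower number from compound 1 to compound 3 (0.95 log units; beyond the scatter). A ring at this place is therefore not required, and tert-butoxy in place of methyl gives an at least 580-fold lower number from compound 2 to compound 3 (2.76 log units; beyond the scatter). That step starts from a limit for compound 2 and not from a number: the limit of >= 100000 nM in this assay, at which 1 of the 3 values shown sits.

Still open, as far as these compounds go, is whether a smaller methoxy group, or an amine such as dimethylamino, on the same carbonyl carbon would keep this gain.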